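Cytotoxicity of two pyrazoline sulfonamides and an unhalogenated analogue

A few compounds are considered here, and "the series" means these few. Any claim that something is new, unique, unknown or untested is made for them only; others in the source may bear on it.

Measured so far:
- compound 1 `NS(=O)(=O)c1ccc(N2N=C(c3ccc(Oc4ccccc4)cc3)CC2c2ccccc2F)cc1`: 32000 nM
- compound 2 `NS(=O)(=O)c1ccc(N2N=C(c3ccc(Oc4ccccc4)cc3)CC2c2ccccc2Cl)cc1`: 8000 nM

In an ADME assay on BHK-21 cells (Mesocricetus auratus) for cytotoxicity, read by MTT assay, with a stated time of 72 h (on this read-out lower numbers stand for higher toxicity in this test and higher numbers for lower toxicity in this test), compound 2 stands lowest of the two numbers measured; its nearest neighbour is compound 1, which differs from it only by fluoro in place of chloro on the aromatic carbon. Going by the values given here, the step of a 4.0-fold lower number from compound 1 to compound 2 (0.60 log units; beyond the scatter) is beyond the scatter and is the only measured step that bears on the next change.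

Compound 3 `NS(=O)(=O)c1ccc(N2N=C(c3ccc(Oc4ccccc4)cc3)CC2c2ccccc2)cc1` carries the change hydrogen in place of chloro on an aromatic carbon relative to compound 2. With one halogen swap already having moved the number by the amount seen between compound 1 and compound 2, taking the halogen away altogether is expected to move the number back toward, and perhaps past, that of compound 1; the step of a 3.8-fold higher number from compound 2 to compound 3 (0.57 log units; beyond the scatter) is the estimate, with compound 2 as the reference. For compound 3 the estimated value in this assay is 30000 nM, with a range from 10000 nM to 90000 nM.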

Compound 3, half-maximal cytotoxic concentration: 11000 nM
Beside the measured number, compound 3's estimate is 2.7-fold (0.44 log units) above it; the range from low to high includes it.
By their numbers in this assay, from the lowest: compounds 2 and 3 (each within the scatter of the next); then compound 1.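

In this assay, hydrogen and chloro on an aromatic carbon ortho to a large group give numbers that cannot be told apart (a 1.4-fold higher number from compound 2 to compound 3 (0.14 log units; within the scatter)), so the 2-chlorophenyl to phenyl change has no readable effect on this read-out. Compound 1 now stands apart from both halogen-free and chloro analogues (a 2.9-fold lower number from compound 1 to compound 3 (0.46 log units; beyond the scatter)), which places the earlier halogen step on the fluoro compound rather than on any rise in toxicity from chloro. Nothing available accounts for why the fluoro compound stands apart.

As far as these compounds go, whether a bromo, methoxy or amine group at this position would read with chloro and hydrogen or with fluoro remains open. Also open, from the compounds shown here alone, is whether the gap between fluoro and hydrogen holds when another part of the shared core is changed.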